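This account rests on a few compounds, and the source may have more. Where it says the series, first, only, none or still open, it means among the compounds named here.

Two compounds sharing one core have been taken into a functional assay on HCT-116 cells (Homo sapiens) for inhibition, read by MTT assay, with a stated time of 48 h (on this read-out higher numbers stand for weaker inhibition and lower numbers for stronger inhibition), so far. For compound 1 (`O=S(=O)(c1ccccc1)c1c(OCCCCCCO)no[n+]1[O-]`) the entry in this assay reads "not determined" (no result reported) and gives no result. Among the measured compounds shown here, compound 2 (`O=C(CCCCCCOc1no[n+]([O-])c1S(=O)(=O)c1ccccc1)NO`) gives 4690 nM in the same test, the only number available, so it cannot yet be ranked against any other compound. Compound 3 (`O=C(CCCCCCCOc1no[n+]([O-])c1S(=O)(=O)c1ccccc1)NO`) has not yet been measured. Its difference from compound 2 is (hydroxycarbamoyl)methyl in place of hydroxycarbamoyl on a saturated chain carbon, six bonds along the chain from an oxygen on an aromatic ring and amounts to (hydroxycarbamoyl)methyl in place of hydroxycarbamoyl on a saturated chain carbon, six bonds along the chain from an oxygen on an aromatic ring. For the measured compounds named here, no measured pair shows what such a change does in this assay, so only a small step is expected, leaning towards stronger inhibition and staying within the usual scatter. The expected change is a 1.4-fold lower number from compound 2 to compound 3 (0.15 log units; within the scatter) and remains a tentative estimate. That expectation has a single anchor, compound 2 at 4690 nM in this series. For compound 3 the estimated value is 3300 nM within an expected range of 1200 nM to 9000 nM in this test.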

Compound 3, half-maximal inhibitory concentration: 2610 nM
Beside the measured number, compound 3's estimate is 1.3-fold (0.10 log units) above it; low and high end bracket the measured number.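

In this assay, among the compounds shown here, the swap of hydroxycarbamoyl for (hydroxycarbamoyl)methyl on a saturated chain carbon, six bonds along the chain from an oxygen on an aromatic ring, gives a 1.8-fold lower number from compound 2 to compound 3 (0.25 log units; within the scatter) and is the first step that can be read at all. At this position the change therefore leaves the two numbers indistinguishable, and a chain carrying the (hydroxycarbamoyl)methyl group still gives a measured value on the shared core, so this single pair shows no sensitivity to the swap. Nothing in the data shown bears on why the number stands where it does.

Compound 1, which ends in a hydroxyl group rather than a hydroxycarbamoyl group, offers no number, so any step involving it cannot be read and the contribution of the hydroxycarbamoyl end remains unsettled. Going by these compounds, it also stays open whether a longer chain such as 2-(hydroxycarbamoyl)ethyl or 3-(hydroxycarbamoyl)propyl, or a carboxylic acid in place of the hydroxycarbamoyl group, would move the number beyond the usual scatter.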